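The compounds below may be only part of what the source reports. "The series", "measured", "known", "first", "only" and "open" are said of these compounds alone.

Measured in an ADME assay on Raji cells (Homo sapiens) for cytotoxicity, with a stated time of 72 h; a higher number here means that more compound is needed for the effect, a lower number that less compound is needed:
- Compound 1 `CC(=O)c1ccc(NC(=O)Nc2cc(C)nc3ccccc23)cc1`: > 25000 nM, a limit
- Compound 2 `Cc1cc(NC(=O)Nc2ccc(C(N)=O)cc2)c2ccccc2n1`: > 25000 nM, a limit
- Compound 3 `Cc1cc(NC(=O)Nc2ccc(SC(F)(F)F)cc2)c2ccccc2n1`: 10000 nM

Among these, compound 3 holds the only actual number, 10000 nM. The other two compounds stand at the limit of > 25000 nM in this assay, at which 2 of the 3 values shown sit.

The next compound, compound 4 `Cc1cc(NC(=O)Nc2ccc(N)cc2)c2ccccc2n1`, has amino in place of (trifluoromethyl)sulfanyl on an aromatic carbon, para to a large group (amino in place of (trifluoromethyl)sulfanyl on an aromatic carbon). Within the data shown here, two measured steps bear on this change, as (trifluoromethyl)sulfanyl enters at the same place in both. One is an at least 2.5-fold lower number from compound 1 to compound 3 (0.39 log units; beyond the scatter), where it replaces acetyl. The other is an at least 2.5-fold lower number from compound 2 to compound 3 (0.39 log units; beyond the scatter), where it replaces carbamoyl. Both end at compound 3, so both give only a minimum size, and neither involves amino itself. Compound 4 loses the same group, so a move back toward a higher number in this assay is expected, at least modest in size and quite possibly ending at the limit of the assay. The step that this implies is estimated as a 2.2-fold higher number from compound 3 to compound 4 (0.34 log units; beyond the scatter). For compound 4 the expected value is 22000 nM, with an estimated range from 9000 nM to 40000 nM.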

Compound 4, half-maximal effective concentration: > 25000 nM
Compound 4: a limit, no number (the forecaster's own chance of this, stated with the estimate: 60%); middle value at least 1.1-fold (0.05 log units) from the limit.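

In this assay, among these compounds, amino in place of (trifluoromethyl)sulfanyl on an aromatic carbon, para to a large group, gives an at least 2.5-fold higher number from compound 3 to compound 4 (0.39 log units; beyond the scatter), which is a minimum size and the one readable step that involves amino itself. Compound 4 thus joins compound 1 and compound 2, and among the acetyl, carbamoyl, amino and (trifluoromethyl)sulfanyl groups at this place, only (trifluoromethyl)sulfanyl in compound 3 gives an actual number, with the other three compounds resting at a limit: the limit of > 25000 nM in this assay, at which 3 of the 4 values shown sit. The steps from compound 1 to compound 4 and from compound 2 to compound 4 cannot be read, since both ends of each are limits, so the acetyl, carbamoyl and amino groups cannot be ordered among themselves.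

The compounds shown leave open whether the number in compound 3 belongs to the (trifluoromethyl)sulfanyl group as a whole, and a trifluoromethyl group, a methylsulfanyl group or a chlorine at the same place could show whether other groups also bring a number under the limit. Going by these compounds, how far compound 1, compound 2 and compound 4 each lie past the limit also stays unknown.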